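1H-pyrazol-4-yl in place of 1H-pyrazol-3-yl: compound 3

This account rests on a few compounds, and the source may have more. Where it says the series, first, only, none or still open, it means among the compounds named here.

Going by the values given here, in a physicochemical assay for lipophilicity, using the shake flask method, in phosphate buffer, measured as octanol-water partition, at pH 7.4 (on this read-out lower numbers stand for lower lipophilicity and higher numbers for higher lipophilicity), compound 1 (`Cn1ccc(-c2cn3nccc3c(-c3cnn([C@]4(CC#N)C[C@H](C#N)C4)c3)n2)n1`) gives 1.6 and compound 2 (`N#CC[C@]1(n2cc(-c3nc(-c4cc[nH]n4)cn4nccc34)cn2)C[C@@H](C#N)C1`) gives 1.7 here, so compound 2 stands level with its only measured neighbour. Among the compounds with values here, compound 3 (`N#CC[C@]1(n2cc(-c3nc(-c4cn[nH]c4)cn4nccc34)cn2)C[C@@H](C#N)C1`) has the same atoms as compound 2, joined differently, with 1H-pyrazol-4-yl in place of 1H-pyrazol-3-yl on an aromatic carbon as the sole change. Within the data shown here, one measured step bears on this only indirectly: hydrogen in place of methyl on an aromatic nitrogen gave a number 0.10 log units higher from compound 1 to compound 2 (within the scatter) in that exchange. Among the measured compounds shown here, no measured step covers the exchange of the two pyrazolyl groups, so no direction can be argued and no step beyond the scatter is expected in this assay for now. The estimated step is a number 0.10 log units lower from compound 2 to compound 3 (within the scatter) on present evidence. The expected value for compound 3 is 1.6 with a range from 1.2 to 2 in this estimate.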

Compound 3, distribution coefficient: 1.6
Compound 3: the middle estimate sits on the measured number at the digits printed; the range from low to high includes it.
By their numbers in this assay, from the lowest: compounds 1, 3 and 2 (each within the scatter of the next).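

In this assay, 1H-pyrazol-4-yl in place of 1H-pyrazol-3-yl on an aromatic carbon gives a number 0.10 log units lower from compound 2 to compound 3 (within the scatter) and so does not separate the two pyrazolyl attachments at this position. Set against the methylated group, 1H-pyrazol-4-yl in place of 1-methyl-1H-pyrazol-3-yl gives no change at the digits printed from compound 1 to compound 3 (within the scatter) and adds a second exchange at the same aromatic carbon, so all three groups tested there now lie within the scatter of one another on this read-out. No measurement at hand explains this result.

Still open, on these data alone, is whether the same holds for a group other than a pyrazolyl ring at this position, such as a primary amine or a carboxylic acid. Also open, as far as these compounds go, is whether 1-methyl-1H-pyrazol-4-yl would fall with these three, and whether any of this carries over once the shared core or its two nitrile groups are changed.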